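The source may report more compounds than this note shows. Statements on the series, on what has been measured and on what is new or still open speak of the compounds shown alone.

In a functional assay on PC-3 cells (Homo sapiens) for antiproliferative activity, read by sulforhodamine B assay, with a stated time of 72 h (a higher number here means a weaker inhibitor, a lower number a stronger inhibitor), compound 1 `COc1ncc(-c2ccc3ncc(NCc4ccccc4)c(OC)c3c2)cc1NS(=O)(=O)c1ccc(F)cc1F` gives 4320 nM, compound 2 `COc1ncc(-c2ccc3ncc(NCC4CCCCC4)c(OC)c3c2)cc1NS(=O)(=O)c1ccc(F)cc1F` gives 9000 nM and compound 3 `COc1ncc(-c2ccc3ncc(NCC4CCN(C(C)=O)CC4)c(OC)c3c2)cc1NS(=O)(=O)c1ccc(F)cc1F` gives 2570 nM. Compound 3 therefore stands level with one neighbour and clear of the other: a 1.7-fold lower number from compound 1 to compound 3 (0.23 log units; within the scatter), but a 3.5-fold lower number from compound 2 to compound 3 (0.54 log units; beyond the scatter). Compound 4 `COc1ncc(-c2ccc3ncc(NCC4CCN(S(C)(=O)=O)CC4)c(OC)c3c2)cc1NS(=O)(=O)c1ccc(F)cc1F` carries methylsulfonyl in place of acetyl on an amine nitrogen in a ring, (methylsulfonyl in place of acetyl on an amine nitrogen in a ring). Among the measured compounds shown here, no measured pair makes this exact change. The nearest evidence is the exchange of the whole group on the saturated chain carbon, which stayed modest at most: a 2.1-fold higher number from compound 1 to compound 2 (0.32 log units; beyond the scatter). In this assay, no shift beyond the scatter is therefore expected, and the expected step is a 1.1-fold higher number from compound 3 to compound 4 (0.04 log units; within the scatter). Compound 4 is estimated at 2800 nM, with an expected range of 1200 nM to 6500 nM.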

Compound 4, half-maximal inhibitory concentration: 2850 nM
Compound 4: middle estimate off by 1.0-fold (0.01 log units), on the low side; low and high end bracket the measured number.
By their numbers in this assay, from the lowest: compounds 3, 4 and 1 (each within the scatter of the next); then compound 2.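

In this assay, methylsulfonyl can take the place of acetyl on the amine nitrogen in a ring with no shift beyond the scatter (a 1.1-fold higher number from compound 3 to compound 4 (0.04 log units; within the scatter)). The advantage over the cyclohexyl of compound 2 survives this exchange (a 3.2-fold lower number from compound 2 to compound 4 (0.50 log units; beyond the scatter)), while compound 4 stays within the scatter of the phenyl of compound 1 (a 1.5-fold lower number from compound 1 to compound 4 (0.18 log units; within the scatter)). Nothing available here explains why the two groups read alike.

Still open, going by these compounds, is whether that nitrogen needs such a group at all, since the free secondary amine is absent from these compounds. Neither a simple methyl nor a larger benzoyl group on it appears here.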